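The compounds below may be only part of what the source reports. "The series", "measured", "known", "first", "only" and "open" are said of these compounds alone.

Compound 1 `COc1ccc(N2CCN(C)CC2)cc1Nc1ncc(F)c(Nc2ccc(F)cc2)n1` gives 960 nM
Compound 2 `O=C(Nc1ccc(C(F)(F)F)cc1)c1cccc(Nc2ncc(F)c(Nc3ccc(F)cc3)n2)c1` gives > 10000 nM as a limit of the assay, not a number
Compound 3 `O=C(Nc1cccc(Nc2ncc(F)c(Nc3ccc(F)cc3)n2)c1)c1cccc([N+](=O)[O-])c1` gives 15100 nM

In a functional assay on KB cells (Homo sapiens) for antiproliferative activity, read by sulforhodamine B assay, with a stated time of 3 days (on this read-out lower numbers stand for stronger inhibition of growth and higher numbers for weaker inhibition of growth), compound 3 stands at 15100 nM as the higher of the two true numbers, and compound 1 lies lower at 960 nM by a gap beyond the scatter. Compound 4 `COCC(=O)Nc1cccc(Nc2ncc(F)c(Nc3ccc(F)cc3)n2)c1` carries methoxymethyl in place of 3-nitrophenyl on a carbonyl carbon and otherwise matches compound 3. Within the data shown here, no measured pair shows this change, so the expectation is tentative and starts from compound 3 at 15100 nM on the weak side of the numbers. A moderate fall in this assay is expected, an estimated step of a 3.0-fold lower number from compound 3 to compound 4 (0.48 log units; beyond the scatter) toward stronger inhibition of growth. For compound 4 the estimate is 5000 nM with an expected range from 1300 nM to 18000 nM in this measurement.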

Compound 4, concentration for 50% growth inhibition: 6250 nM
Estimate against measurement, compound 4: 1.3-fold (0.10 log units) below; the measured number falls inside the stated range.
By their numbers in this assay, from the lowest: compound 1; then compound 4; then compound 3.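

Among these compounds, putting methoxymethyl in place of 3-nitrophenyl on a carbonyl carbon gives a 2.4-fold lower number from compound 3 to compound 4 (0.38 log units; beyond the scatter) in this assay, the first sign that the group at this position changes the read-out. The six-membered aromatic ring of carbon is not needed for the growth inhibition seen here, since a smaller group without a ring does not weaken it.

From the compounds shown here alone, whether an amine, a carboxylic acid or a longer chain at this place would lower the number further stays open. Compound 2 offers only a limit of the assay, not a number: the limit of > 10000 nM in this assay, at which 1 of the 4 values shown sits.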